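Dropping the chloro from compound 3's benzylidene ring

The source may report more compounds than this note shows. Statements on the series, on what has been measured and on what is new or still open speak of the compounds shown alone.

Of the compounds shown here, three sharing one core have been measured in a functional assay on HeLa cells (Homo sapiens) for cytotoxicity, read by MTT assay, with a stated time of 48 h, tested at 50 uM; on this read-out higher numbers stand for a stronger effect at the one concentration tested and lower numbers for a weaker effect. Compound 1 `CSc1ccc(/C=N/n2c(Cc3ccc(S(C)(=O)=O)cc3)n[nH]c2=S)cc1` gives 57.5%. Compound 2 `CS(=O)(=O)c1ccc(Cc2n[nH]c(=S)n2/N=C/c2ccc(Cl)cc2)cc1` gives 54% in this assay, and compound 3 `CS(=O)(=O)c1ccc(Cc2n[nH]c(=S)n2/N=C/c2c(F)cccc2Cl)cc1` gives 70.6%. Between the first two the read-out is a number 3.5 percentage points lower from compound 1 to compound 2 (within the scatter). Compound 3 stands highest of the three, since the read-out is a number 13.1 percentage points higher from compound 1 to compound 3 (beyond the scatter) and a number 16.6 percentage points higher from compound 2 to compound 3 (beyond the scatter), both steps beyond the scatter.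

Compound 4 `CS(=O)(=O)c1ccc(Cc2n[nH]c(=S)n2/N=C/c2ccccc2F)cc1` is the next case. Its change from compound 3 is hydrogen in place of chloro on an aromatic carbon. Only the two steps into compound 3 bear on this, and both came from exchanging the whole aryl group, not one chloro alone; compound 4 keeps the fluoro and loses the chloro, so it sits partway between the measured cases. The expectation for compound 4 in this assay is therefore a modest fall, a number 9.6 percentage points lower from compound 3 to compound 4 (within the scatter), toward the other two numbers. Compound 4 is estimated at 61%, with a range from 48% to 74%.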

Compound 4, a percentage reported as activity, at one concentration (the size of the read-out at that concentration, not a potency): 21.9%
Beside the measured number, compound 4's estimate is 39.1 percentage points above it; the measured number lies below the stated range.
By their numbers in this assay, from the lowest: compound 4; then compounds 2 and 1 (each within the scatter of the next); then compound 3.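

Taking one chloro off the 2-chloro-6-fluorophenyl group is a large change in this assay, a number 48.7 percentage points lower from compound 3 to compound 4 (beyond the scatter), whereas the earlier exchanges of a whole aryl group gave only modest steps. The 2-fluorophenyl group also falls well short of the two other aryl groups, with a number 32.1 percentage points lower from compound 2 to compound 4 (beyond the scatter) and a number 35.6 percentage points lower from compound 1 to compound 4 (beyond the scatter), so among these compounds the fluoro alone does not keep the higher number of compound 3, and a single chlorine atom separates the highest number from the lowest. Nothing shown here bears on why this one atom matters so much.

Still open, going by these compounds, is whether the chloro is specifically needed, or whether a methyl, a methoxy or an amine on the same carbon would hold the number up. Also open, on these data alone, is whether the chloro would do the same with hydrogen in place of the fluoro.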